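The source may report more compounds than this note shows. Statements on the series, on what has been measured and on what is new or still open speak of the compounds shown alone.

Compound 1 `COc1cc(SC)nc(NC(=S)NC(=O)c2c(-c3ccc(Cl)cc3Cl)noc2C)n1` gives, in a functional assay on the whole organism (strain L.) for inhibition, with Echinochloa crus-galli as the target, with a stated time of 72 h, tested at 10 mg/L (on this read-out lower numbers stand for less inhibition of growth and higher numbers for more inhibition of growth at the one concentration tested), a value of 19.3%, the lowest of the three numbers at hand, though compound 3 sits within the scatter of it. The other two measured compounds share a different core: compound 2 `COc1cc(C)nc2n/c(=N/C(=O)c3c(-c4ccc(Cl)cc4Cl)noc3C)sn12` gives 30.9% in this assay, beyond the scatter from compound 1, while compound 3 `COc1cc(SC)nc2n/c(=N/C(=O)c3c(-c4ccc(Cl)cc4Cl)noc3C)sn12` gives 21.4% in this assay. Among the compounds with values here, the only step between measured compounds, a number 9.5 percentage points lower from compound 2 to compound 3 (within the scatter), alters a substituent on an aromatic carbon of that other core and stays within the scatter. Compound 4 `Cc1cc(Cl)nc(NC(=S)NC(=O)c2c(-c3ccc(Cl)cc3Cl)noc2C)n1` arises from compound 1 by 4-chloro-6-methylpyrimidin-2-yl in place of 4-methoxy-6-(methylsulfanyl)pyrimidin-2-yl on an amide-type nitrogen. Within the data shown here, no measured pair alters that part of compound 1, so no direct guide exists; the one ring-substituent step seen on the other core was small. For compound 4 the step of a number 2.7 percentage points higher from compound 1 to compound 4 (within the scatter) is therefore expected to stay within the scatter. Compound 4 is estimated at 22%, with a range from 5% to 45%.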

Compound 4, percent growth inhibition at one concentration: -6.84%
The estimate for compound 4 lay 28.8 percentage points above the measured number, and the stated range ends above it.
By their numbers in this assay, from the lowest: compound 4; then compounds 1, 3 and 2 (each within the scatter of the next, the first and the last beyond it).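

In this assay, putting 4-chloro-6-methylpyrimidin-2-yl in place of 4-methoxy-6-(methylsulfanyl)pyrimidin-2-yl on the amide-type nitrogen gives a number 26.1 percentage points lower from compound 1 to compound 4 (beyond the scatter) and so shows that the read-out responds to this group, a response the one earlier step, a number 9.5 percentage points lower from compound 2 to compound 3 (within the scatter) on the other core, had not shown. Because the entering group differs from the leaving one in both ring substituents, this single step cannot say whether the chloro or the methyl accounts for the change. Nothing at hand gives a reason for the step.

The compounds shown leave open how a pyrimidin-2-yl group carrying only one of these changes, such as chloro with methylsulfanyl, would compare. They also leave open what an amine or an ethoxy group on that ring would do.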